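The source may hold more compounds than are shown below. What is called first, only, known or untested is meant among the compounds shown, and "the series" means these compounds.

The measured compounds:
compound 1, `Nc1cccc(Nc2nc(N/N=C/c3ccc(F)cc3)ncc2Cl)c1`; in an ADME assay on HT-29 cells (Homo sapiens) for inhibition, read by MTT assay, with a stated time of 72 h (on this read-out lower numbers stand for stronger inhibition and higher numbers for weaker inhibition), compound 1 gives 12300 nM
compound 2, `C=CC(=O)Nc1cccc(Nc2nc(N/N=C(\C)c3ccc(F)cc3)ncc2Cl)c1`; compound 2 gives 5050 nM
compound 3, `C=CC(=O)Nc1cccc(Nc2nc(N/N=C(\C)c3cccc(OC)c3)ncc2Cl)c1`; compound 3 gives 8990 nM

Compound 1 holds the highest of the three numbers. Compound 3 lies within the scatter of it, while compound 2 sits beyond the scatter below it. Compound 4, `CN(C)C/C=C/C(=O)Nc1cccc(Nc2nc(N/N=C/c3ccc(F)cc3)ncc2Cl)c1`, is built from compound 1 by (3-(dimethylamino)prop-1-en-1-yl)carbonyl in place of hydrogen on a nitrogen on an aromatic ring. Within the data shown here, the only step between single-change neighbours, a 1.8-fold higher number from compound 2 to compound 3 (0.25 log units; within the scatter), concerns the aryl group on the carbon with a double bond to nitrogen and does not touch the changed nitrogen. Compound 2 differs from compound 1 in two places, the chain on that nitrogen and a methyl on the carbon with a double bond to nitrogen, so its lower number only hints that a carbonyl-bearing chain there goes with a lower number. On that hint, compound 4 is expected to give a modestly lower number than compound 1, a step of a 2.2-fold lower number from compound 1 to compound 4 (0.35 log units; beyond the scatter), with wide uncertainty. The estimate for compound 4 in this assay is 5500 nM, within 2000 nM to 15000 nM.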

Compound 4, half-maximal inhibitory concentration: 3300 nM
For compound 4 the middle estimate is 1.7-fold (0.22 log units) above the measured one; the range from low to high includes it.
By their numbers in this assay, from the lowest: compounds 4, 2, 3 and 1 (each within the scatter of the next, the first and the last beyond it).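

In this assay, among these compounds, the step of a 3.7-fold lower number from compound 1 to compound 4 (0.57 log units; beyond the scatter) gives the first single-change reading at the nitrogen on an aromatic ring: amino to ((3-(dimethylamino)prop-1-en-1-yl)carbonyl)amino goes with a lower number while the rest of compound 1 stays the same. Earlier, this nitrogen was changed only in compound 2, together with a methyl on the carbon with a double bond to nitrogen, so neither change could be read alone. Nothing measured here explains the step.

The compounds shown leave open which part of the chain goes with the lower number, since this one pair cannot separate the carbonyl, the double bond and the dimethylamino group. An acetyl group on that nitrogen, or a morpholine in place of the dimethylamino group, would bear on that question.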